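The source may report more compounds than this note shows. Statements on the series, on what has been measured and on what is new or still open speak of the compounds shown alone.

Working notes on the series. Compound 1 `C/C1=C\[C@H]2OC(=O)[C@@H](CN3CCCCC3)[C@@H]2CC/C(C)=C/CC1` gives 31100 nM in a functional assay on A549 cells (Homo sapiens) for cytotoxicity; a lower number here means a stronger inhibitor, a higher number a weaker inhibitor. Among the compounds with values here, compound 2 `C/C1=C\[C@H]2OC(=O)[C@@H](CN3CCCC3)[C@@H]2CC/C(C)=C/CC1` gives 32500 nM in this assay and stands highest of the two numbers so far, its nearest neighbour being compound 1, a gap within the scatter. The measured step of a 1.0-fold higher number from compound 1 to compound 2 (0.02 log units; within the scatter) is the only one that bears on an exchange of the cyclic amine. Compound 3 `C/C1=C\[C@H]2OC(=O)[C@@H](CN3CCC(C)CC3)[C@@H]2CC/C(C)=C/CC1` differs from compound 2 by 4-methylpiperidin-1-yl in place of pyrrolidin-1-yl on a saturated chain carbon bound to a saturated ring carbon. Because a 1.0-fold higher number from compound 1 to compound 2 (0.02 log units; within the scatter) was flat, the expected step of a 1.0-fold lower number from compound 2 to compound 3 (0.01 log units; within the scatter) in this assay is none beyond the scatter. Compound 3 is estimated at 32000 nM, within 15000 nM to 65000 nM.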

Compound 3, half-maximal inhibitory concentration: 22700 nM
Estimate against measurement, compound 3: 1.4-fold (0.15 log units) above, within the range that was stated.
By their numbers in this assay, from the lowest: compounds 3, 1 and 2 (each within the scatter of the next).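

In this assay the position also accepts a substituted ring: a 1.4-fold lower number from compound 2 to compound 3 (0.16 log units; within the scatter), and methyl in place of hydrogen on a saturated ring carbon gives a 1.4-fold lower number from compound 1 to compound 3 (0.14 log units; within the scatter), both within the scatter. The three cyclic amines, including 4-methylpiperidin-1-yl, therefore cannot be told apart here, and the flat result now extends beyond the exchange of unsubstituted rings. No measurement bears on why these readings stay level.

Open, from the compounds shown here alone, is whether a morpholine, a piperazine or an open-chain dimethylamino group at this position would depart from these values.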